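Extending the Chain Beyond the Fluorophenyl Amide

This account rests on a few compounds, and the source may have more. Where it says the series, first, only, none or still open, it means among the compounds named here.

Measured so far:
Compound 1 `O=C(CCc1ccccc1Br)Nc1nc2ccccc2c(=O)s1` gives 2.09 nM
Compound 2 `O=C(CCc1ccccc1F)Nc1nc2ccccc2c(=O)s1` gives 11.2 nM

Both compounds were tested in an in vitro assay on cells for inhibition of Amine oxidase [flavin-containing] B (Homo sapiens), read by fluorescence and Amplex Red, with stated times of 30 min and 45 min; a lower number here means a stronger inhibitor, a higher number a weaker inhibitor. Among the measured compounds shown here, compound 2 stands at the higher of the two numbers: the single step of a 5.4-fold higher number from compound 1 to compound 2 (0.73 log units; beyond the scatter) separates it from compound 1, so compound 2 is the weaker inhibitor of the pair in this assay.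

Compound 3 `O=C(CCCc1cccc(Cl)c1)Nc1nc2ccccc2c(=O)s1` differs from compound 2 by 3-chlorobenzyl in place of 2-fluorophenyl on a saturated chain carbon, two bonds along the chain from a carbonyl carbon. For the measured compounds named here, no measured step covers this change directly. Going by the values given here, the only step available, a 5.4-fold higher number from compound 1 to compound 2 (0.73 log units; beyond the scatter), concerns the identity of the halogen alone, and it shows that going from bromine to fluorine raised the number by a modest margin. Among the compounds with values here, compound 3 moves back toward a heavier halogen, chlorine, while also lengthening the chain and placing the halogen differently on the ring; the latter two changes have no measured counterpart here. The expectation for compound 3 is therefore a somewhat lower number than compound 2, with wide uncertainty, as the step of a 1.9-fold lower number from compound 2 to compound 3 (0.27 log units; within the scatter). Compound 3 is estimated at 6 nM, in a range from 1.5 nM to 25 nM.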

Compound 3, half-maximal inhibitory concentration: > 1000 nM
Compound 3 gave a limit, no number (the forecaster's own chance of this, stated with the estimate: 2%); middle value at least 160-fold (2.22 log units) from the limit.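

Compound 3 gives no number in this assay, only a limit: the limit of > 1000 nM in this assay, at which 1 of the 3 values shown sits. This place, on a saturated chain carbon, two bonds along the chain from a carbonyl carbon, proves highly sensitive to the group it carries: 3-chlorobenzyl in place of 2-fluorophenyl brings an at least 89-fold higher number from compound 2 to compound 3 (1.95 log units; beyond the scatter), and 3-chlorobenzyl in place of 2-bromophenyl brings an at least 470-fold higher number from compound 1 to compound 3 (2.67 log units; beyond the scatter). The earlier pair showed only a modest shift on exchanging one halogen for another, a 5.4-fold higher number from compound 1 to compound 2 (0.73 log units; beyond the scatter), whereas compound 3 shows that a halogen on the aromatic ring is not in itself enough to keep the number low.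

The change to 3-chlorobenzyl alters both the link to the ring and the place of the halogen on it, so the compounds shown do not tell which of the two accounts for the large step. From the compounds shown here alone, a 3-chlorophenyl group would test the place of the halogen alone and a 2-chlorobenzyl group the longer link alone, while the effect of an unsubstituted benzyl group or an amine at this place remains open.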